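The compounds below may be only part of what the source reports. "The series", "measured", "known", "first", "only" and "open" are said of these compounds alone.

Among the measured compounds shown here, compound 2 `CC(=O)COc1cc(=O)oc2cc(OCc3cccc(Cl)c3)ccc12` stands highest of the two numbers known so far: in an assay on isolated protein (strain Sprague-Dawley) for inhibition of Amine oxidase [flavin-containing] A (Rattus norvegicus), read by spectrophotometry, with a stated time of 5 min, tested at 10 uM (on this read-out higher numbers stand for more inhibition at the one concentration tested (going by the name of the read-out) and lower numbers for less inhibition), compound 2 gives 22%. For the measured compounds named here, compound 1 `O=c1cc(O)c2ccc(OCc3cccc(Br)c3)cc2o1`, the only other measured compound, gives 0% in this assay, a gap beyond the usual scatter. Compound 3 `CNC(=O)COc1cc(=O)oc2cc(OCc3cccc(Cl)c3)ccc12` is not yet measured. It differs from compound 2 in one place: methylamino in place of methyl on a carbonyl carbon. Going by the values given here, no measured pair shows this kind of change, so the step is expected to be small, within the scatter and without a clear direction, namely a number 2 percentage points lower from compound 2 to compound 3 (within the scatter). Compound 3 is therefore estimated at 20% in this assay, with a range from 5% to 40%.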

Compound 3, a percentage reported as inhibition, at one concentration (the size of the read-out at that concentration, not a potency): 11%
For compound 3 the middle estimate is 9 percentage points above the measured one; measured number inside the range.
By their numbers in this assay, from the lowest: compound 1; then compound 3; then compound 2.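

Among the compounds shown here, replacing methyl with methylamino on a carbonyl carbon gives a number 11 percentage points lower from compound 2 to compound 3 (beyond the scatter) in this assay and so provides the first readable one-place comparison in this set. It shows that the group at the end of this chain can alter inhibition at the one concentration tested, and that this amide does not improve on the ketone. Nothing measured here accounts for the fall.

Whether the amide hydrogen matters remains open, since dimethylamino on the same carbonyl carbon is not among the compounds shown. From the compounds shown here alone, how a carboxylic acid or a longer chain at this place would read also remains open.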